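From Bromo to Nitro at the Assay Limit

The compounds below may be only part of what the source reports. "The series", "measured", "known", "first", "only" and "open" are said of these compounds alone.

Compound 1 `CCOC(=O)c1c(-c2cccc(OCC)c2)[nH]c2cc(OC)ccc2c1=O`: > 21500 nM
Compound 2 `CCOC(=O)c1c(-c2cccc(F)c2)[nH]c2cc(OC)ccc2c1=O`: > 21500 nM
Compound 3 `CCOC(=O)c1c(-c2cccc(Br)c2)[nH]c2cc(OC)ccc2c1=O`: > 21500 nM

All three compounds were tested in an ADME assay on Raji cells (Homo sapiens) for cytotoxicity, read by luminescence, with a stated time of 72 h (a lower number here means that less compound is needed, a higher number that more compound is needed for the effect), and each result is a limit, not a number. Compound 3 stands at > 21500 nM, which is a limit. It shares this position with the other two compounds, as the series shows only (the limit of > 21500 nM in this assay, at which 3 of the 3 values shown sit).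

Compound 4 `CCOC(=O)c1c(-c2cccc([N+](=O)[O-])c2)[nH]c2cc(OC)ccc2c1=O` has not yet been measured. It carries nitro in place of bromo on an aromatic carbon, the change from 3-bromophenyl to 3-nitrophenyl, and otherwise keeps the shared core.

For the measured compounds named here, three measured steps bear on this change, each exchanging one group on an aromatic carbon. They are a step that the two limits leave unreadable from compound 1 to compound 2, a step that the two limits leave unreadable from compound 1 to compound 3 and a step that the two limits leave unreadable from compound 2 to compound 3. The last is the closest guide, since bromo enters there, but none of the three gives a size. The data therefore support no expected direction in this assay, and compound 4 is expected to report a limit as well. The estimated change is a number no higher from compound 3 to compound 4 (the limit leaves the size open), with no shift beyond the scatter expected.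

For compound 4 the estimated value is 21500 nM, with an expected range from 10000 nM to 40000 nM.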

Compound 4, half-maximal effective concentration: > 21500 nM
Compound 4: only a limit was reported (the forecaster's own chance of this, stated with the estimate: 85%); the middle value sits exactly at the limit.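

In this assay compound 4 gives > 21500 nM, which is a limit. No new step can be read from it: its steps from compound 1, compound 2 and compound 3 all remain unreadable. The compounds shown leave open how much of each is needed for the effect, and whether exchanging these groups changes that amount at all: the limit of > 21500 nM in this assay, at which 4 of the 4 values shown sit.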